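Change at the Amide End, Basic Nitrogen Untouched

This account rests on a few compounds, and the source may have more. Where it says the series, first, only, none or still open, it means among the compounds named here.

Of the compounds shown here, three have been measured in a physicochemical assay for acid dissociation. Compound 1 `CC(C)N1CCC(Oc2ccc3nc(C(=O)N4CCC4)ccc3c2)CC1` gives 9.5. Compound 2 `CC1CCN(C(=O)c2ccc3cc(OC4CCN(C(C)C)C4)ccc3c2)CC1` gives 9.4. Compound 3 `COC1CCN(C(=O)c2ccc3cc(OCCCN4CCCCC4)ccc3c2)CC1` gives 9.57. Compound 3 stands apart from neither of the others: its gaps to compound 1 and to compound 2 both lie within the usual scatter of this kind of measurement, so none of the three numbers can be placed above or below another.

Compound 4 `O=C(c1ccc2cc(OCCCN3CCCCC3)ccc2c1)N1CCC(CO)CC1` has not yet been measured in this assay. It differs from compound 3 in one place: hydroxymethyl in place of methoxy on a saturated ring carbon. Among the compounds with values here, no measured pair shows this same change, so no step can be read directly from the data. What the data do show is that compounds 1, 2 and 3 carry three different amide partners and still fall within the scatter of one another. On that basis a step no larger than the scatter is expected, in no particular direction, a number 0.02 log units lower from compound 3 to compound 4 (within the scatter). Compound 4 is therefore estimated at 9.55, within a range from 9.3 to 9.8.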

Compound 4, acid dissociation constant: 9.6
Beside the measured number, compound 4's estimate is 0.05 log units below it; the measured number falls inside the stated range.
By their numbers in this assay, from the lowest: compounds 2, 1, 3 and 4 (each within the scatter of the next).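

Within the data shown here, the step of a number 0.03 log units higher from compound 3 to compound 4 (within the scatter) in this assay is the first direct reading of methoxy giving way to hydroxymethyl on a saturated ring carbon, three ring bonds from the ring nitrogen. The two groups have the same heavy atoms, but hydroxymethyl carries a hydrogen-bond donor that methoxy lacks, and in this pair that exchange leaves no difference that can be told from the scatter. No measurement at hand bears on why the two numbers stay so close.

As far as these compounds go, whether a group of a different kind on this ring carbon, such as an amine or a carboxylic acid, would also stay within the scatter remains open. So does the outcome for a longer chain, such as hydroxyethyl, at the same place.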